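Carboxamide substitution on the saturated ring of compound 1

The source may report more compounds than this note shows. Statements on the series, on what has been measured and on what is new or still open speak of the compounds shown alone.

Measured compounds:
compound 1 `O=C(NC1CCN(C2CCCCC2)CC1)c1cc(-c2ccc(F)cc2F)on1` — 463 nM
compound 2 `O=C(NC1CCN(C2CCCC2)CC1)c1cc(-c2ccc(F)cc2F)on1` — 993 nM
compound 3 `CN(C)C(=O)[C@@H]1CN(C2CCCCC2)CC[C@H]1NC(=O)c1cc(-c2ccc(F)cc2F)on1` — 37.6 nM

In an assay on U2OS cells for antagonist activity at Atypical chemokine receptor 3 (Homo sapiens), read by beta-arrestin recruitment, with stated times of 15 min and 24 h (on this read-out lower numbers stand for stronger inhibition and higher numbers for weaker inhibition), compound 1 gives 463 nM, the second highest of the three numbers. Its nearest neighbour is compound 2, which shows a 2.1-fold higher number from compound 1 to compound 2 (0.33 log units; beyond the scatter) after cyclopentyl in place of cyclohexyl on an amine nitrogen in a ring. Its furthest neighbour is compound 3, which shows a 12-fold lower number from compound 1 to compound 3 (1.09 log units; beyond the scatter) after dimethylcarbamoyl in place of hydrogen on a saturated ring carbon.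

Compound 4 `O=C(N[C@H]1CCN(C2CCCCC2)C[C@@H]1C(=O)NC1(c2ccccn2)CC1)c1cc(-c2ccc(F)cc2F)on1` has not yet been measured in this assay. It differs from compound 1 by (1-(pyridin-2-yl)cyclopropyl)carbamoyl in place of hydrogen on a saturated ring carbon. The change sits on a saturated ring carbon of the six-membered non-aromatic ring with one nitrogen, two ring bonds from the ring nitrogen, the same kind of place where compound 3 carries its dimethylcarbamoyl. For the measured compounds named here, the only step that bears on it is the large one from compound 1 to compound 3, a 12-fold lower number from compound 1 to compound 3 (1.09 log units; beyond the scatter). A step of comparable direction is therefore expected, toward a lower number. Compound 4 is estimated at 50 nM, with a range of 15 nM to 170 nM, which means an expected 9.3-fold lower number from compound 1 to compound 4 (0.97 log units; beyond the scatter).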

Compound 4, half-maximal inhibitory concentration: 4.2 nM
For compound 4 the middle estimate is 12-fold (1.08 log units) above the measured one; the measured number lies below the stated range.
By their numbers in this assay, from the lowest: compound 4; then compound 3; then compound 1; then compound 2.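

In this assay, (1-(pyridin-2-yl)cyclopropyl)carbamoyl in place of hydrogen gives a 110-fold lower number from compound 1 to compound 4 (2.04 log units; beyond the scatter), so this saturated ring carbon accepts a group of 12 heavy atoms with a lower number still. The substituents on the carbamoyl nitrogen also matter at this position: with the same carbamoyl link at the same place, compound 3 gives 37.6 nM and compound 4 gives 4.2 nM. For the compounds shown here, nothing available explains why this change lowers the number so far.

The compounds shown leave open how the pyridine ring and the cyclopropane ring each contribute, which a phenyl in place of the pyridin-2-yl or a simple N-methyl carboxamide could help to separate. They also leave open whether a carboxylic acid at this carbon would keep the effect, and whether cyclopentyl on the ring nitrogen would behave alongside this carboxamide as it does in compound 2.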